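A few compounds are considered here, and "the series" means these few. Any claim that something is new, unique, unknown or untested is made for them only; others in the source may bear on it.

Working notes on the series. The three compounds measured to date share one core. Compound 1 is `O=C(c1cccnc1)n1c(-c2cn(-c3ccccc3)nc2-c2ccc(F)cc2)nc2ccccc21`. Compound 2 is `Cc1ccc(-c2nn(-c3ccccc3)cc2-c2nc3ccccc3n2C(=O)c2cncc(C)c2)cc1`. Compound 3 is `O=C(c1ccccc1)n1c(-c2cn(-c3ccccc3)nc2-c2ccc(C(F)(F)F)cc2)nc2ccccc21`. In an ADME assay on HEK-293T cells (Homo sapiens) for cytotoxicity, read by MTT assay, with a stated time of 24 h (a lower number here means that less compound is tolerated, a higher number that more compound is tolerated), compound 1 gives 216000 nM. In this assay compound 2 gives 155000 nM. In this assay compound 3 gives 168000 nM. Compound 3 lies within the usual scatter of both compound 2, the nearest value, and compound 1, the furthest; the three numbers cannot be told apart.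

The next compound, compound 4, is `O=C(c1ccncc1)n1c(-c2cn(-c3ccccc3)nc2-c2ccc(C(F)(F)F)cc2)nc2ccccc21`. Against compound 3 the change is pyridin-4-yl in place of phenyl on a carbonyl carbon. The same kind of exchange, a carbonyl carrying a carbon-only ring or a ring with one nitrogen, already separates compound 3 from compound 1, and those two values sit within the scatter of each other. Among the measured compounds shown here, no measured pair differing in one place is available, so the size of the step cannot be read off directly; on the two values shown, nothing beyond the scatter is expected in either direction for this assay.

For compound 4 the estimated value in this assay is 170000 nM, with a range from 90000 nM to 330000 nM. That estimate means a step from compound 3 to compound 4 of a 1.0-fold higher number from compound 3 to compound 4 (0.01 log units; within the scatter), expected to stay within the scatter.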

Compound 4, half-maximal cytotoxic concentration: 135000 nM
For compound 4 the middle estimate is 1.3-fold (0.10 log units) above the measured one; measured number inside the range.
By their numbers in this assay, from the lowest: compounds 4, 2, 3 and 1 (each within the scatter of the next).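

The exchange of phenyl for pyridin-4-yl on a carbonyl carbon now has its first single-place reading in this assay, a 1.2-fold lower number from compound 3 to compound 4 (0.09 log units; within the scatter). The earlier compounds shown here offered no measured pair differing in one place, whereas this pair shows directly that adding one ring nitrogen and the one hydrogen-bond acceptor counted for pyridin-4-yl leaves the two compounds indistinguishable in this read-out. No measured property bears on this step, so the data offer no account of it.

Among the compounds shown here, this single pair covers only two six-membered aromatic rings on the carbonyl carbon, so it remains open whether a piperidine, a longer alkyl chain or a ring bearing a carboxylic acid at this position would also stay within the scatter. On these data alone, it also remains open whether the benzoyl to (pyridin-4-yl)carbonyl exchange gives a similarly small step when the trifluoromethyl group elsewhere on the shared core is replaced by another group, such as a methoxy group or an amine.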